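This account rests on a few compounds, and the source may have more. Where it says the series, first, only, none or still open, it means among the compounds named here.

Compound 1, with the structure `C=C[C@@](C)(/C=C/c1ccc(Nc2ccc(OC)cc2)cc1)CCC=C(C)C`, is the starting point. In an ADME assay on BJ cells (Homo sapiens) for cytotoxicity, with a stated time of 72 h (on this read-out higher numbers stand for an effect only at larger amounts of compound and lower numbers for an effect already at smaller amounts), compound 1 gives > 36600 nM, which is a limit of the assay rather than a number. Two relatives differ from it in one place. Compound 2, `C=C[C@@](C)(/C=C/c1ccc(Nc2ccc(OC)c(OC)c2)cc1)CCC=C(C)C`, carries a methoxy in place of hydrogen on an aromatic carbon; in this assay compound 2 gives > 36600 nM, again a limit. Compound 3, `C=C[C@@](C)(/C=C/c1ccc(Nc2ccc(C(F)(F)F)cc2)cc1)CCC=C(C)C`, carries a trifluoromethyl in place of methoxy on an aromatic carbon; in this assay compound 3 gives > 36600 nM, also a limit. The steps a step that the two limits leave unreadable from compound 1 to compound 2 and a step that the two limits leave unreadable from compound 1 to compound 3 therefore have no readable size, because of the limit of > 36600 nM in this assay, at which 3 of the 3 values shown sit. Compound 4, `C=C[C@@](C)(/C=C/c1ccc(-c2cccc(F)c2)cc1)CCC=C(C)C`, has not been measured. It differs from compound 1 by 3-fluorophenyl in place of (4-methoxyphenyl)amino on an aromatic carbon. This change is larger than either measured step, and the measured steps give no direction to lean on. The expected step of a number no higher from compound 1 to compound 4 (the limit leaves the size open) is small, with compound 4 expected to give about 36600 nM, in the range 10000 nM to 120000 nM, most likely again reported only as a limit.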

Compound 4, half-maximal effective concentration: > 36600 nM
Compound 4: a limit, no number (the forecaster's own chance of this, stated with the estimate: 70%); the middle value sits exactly at the limit.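

Compound 1 and compound 4 both sit at a limit rather than a number, so no size can be read for the step between them: the limit of > 36600 nM in this assay, at which 4 of the 4 values shown sit. The compounds shown leave open where any of their true values lie in this assay, and whether any change among them alters the read-out.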